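The source may hold more compounds than are shown below. What is called first, only, known or untested is meant among the compounds shown, and "the series" means these compounds.

Compound 1 `Cc1cc(=O)[nH]c(=O)n1COC(CO)CO` and compound 2 `O=c1ccn(COC(CO)CO)c(=O)[nH]1` share the same core and the same side chain. In a functional assay on SW-620 cells (Homo sapiens) for inhibition, read by MTT assay, with a stated time of 72 h (a higher number here means a weaker inhibitor, a lower number a stronger inhibitor), compound 1 gives only a limit, > 100000 nM. In this assay compound 2 likewise gives only a limit, > 100000 nM. Among the compounds with values here, the single measured step, a step that the two limits leave unreadable from compound 1 to compound 2, therefore has no readable size, because of the limit of > 100000 nM in this assay, at which 2 of the 2 values shown sit. Within the data shown here, compound 2 thus stands at the limit of this assay without a number of its own, and the one further value shown beside it is a limit as well.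

Compound 3 `Nc1cn(COC(CO)CO)c(=O)[nH]c1=O` has not yet been measured. It differs from compound 2 by amino in place of hydrogen on an aromatic carbon. Among the measured compounds shown here, no measured step touches an amino group, so the only guide is that neither compound 1 nor compound 2 reached a number within the range of this assay, and the step that the two limits leave unreadable from compound 1 to compound 2 gives neither size nor direction. Compound 3 is therefore expected to stay near or past the limit, with an expected step that the limit leaves unreadable from compound 2 to compound 3. The estimate for compound 3 in this assay is 200000 nM, within 50000 nM to 1000000 nM.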

Compound 3, half-maximal inhibitory concentration: > 100000 nM
Compound 3: a limit, no number; the forecaster's own chance of this, stated with the estimate: 85%; the middle value is on the limit's open side.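

Compound 3, like compound 2, gives only a limit in this assay, so no size or direction can be read for the step between these two compounds: the limit of > 100000 nM in this assay, at which 3 of the 3 values shown sit.

The compounds shown leave open how compound 1, compound 2 and compound 3 rank against one another, and whether any change to the shared core yields a number in this assay.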